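The compounds below may be only part of what the source reports. "The series", "measured", "known", "first", "only" and "open" are said of these compounds alone.

In a functional assay on A549 cells (Homo sapiens) for antiproliferative activity, read by MTT assay (on this read-out higher numbers stand for weaker inhibition and lower numbers for stronger inhibition), compound 1 `Cn1c(=O)c(=O)n(C2CCCC2)c2nc(N/N=C/c3ccc(O)cc3)ncc21` gives > 100000 nM, which is a limit and not a number. Within the data shown here, compound 2 `CSc1ccc(/C=N/Nc2ncc3c(n2)n(C2CCCC2)c(=O)c(=O)n3C)cc1` gives 14100 nM, the only true number so far. Among the measured compounds shown here, the one measured step, an at least 7.0-fold lower number from compound 1 to compound 2 (0.85 log units; beyond the scatter), placed methylsulfanyl in place of hydroxy on an aromatic carbon. Compound 3 `Cn1c(=O)c(=O)n(C2CCCC2)c2nc(N/N=C/c3ccc(F)cc3F)ncc21` has 2,4-difluorophenyl in place of 4-(methylsulfanyl)phenyl on a carbon with a double bond to nitrogen. That earlier step bears on this change only loosely, since it exchanged a different group, so no change beyond the scatter is expected in this assay. The expected step is a 1.1-fold higher number from compound 2 to compound 3 (0.03 log units; within the scatter). The estimated value for compound 3 is 15000 nM, within an expected range of 5000 nM to 60000 nM.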

Compound 3, half-maximal inhibitory concentration: 18300 nM
Compound 3: middle estimate off by 1.2-fold (0.09 log units), on the low side; the measured number falls inside the stated range.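

In this assay, the change at this carbon with a double bond to nitrogen gives a 1.3-fold higher number from compound 2 to compound 3 (0.11 log units; within the scatter), so 2,4-difluorophenyl and 4-(methylsulfanyl)phenyl cannot be told apart here. Replacing 4-hydroxyphenyl with 2,4-difluorophenyl gives an at least 5.4-fold lower number from compound 1 to compound 3 (0.73 log units; beyond the scatter), so two different groups now stand clear of 4-hydroxyphenyl. Compound 1 gives a limit and not a number, so the full size of both steps from it stays unknown: the limit of > 100000 nM in this assay, at which 1 of the 3 values shown sits.

The compounds shown leave open how an aromatic ring carrying an amine or a carboxylic acid would behave in this place.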